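Extending the chain from compound 3 to compound 4

This account rests on a few compounds, and the source may have more. Where it says the series, first, only, none or still open, it means among the compounds named here.

In a functional assay on brain (Rattus norvegicus, strain Wistar) for inhibition (on this read-out lower numbers stand for stronger inhibition and higher numbers for weaker inhibition), compound 1 (`CCCCc1ccc(-c2c(C)[nH]c(=O)n2C)cc1`) reads 10700 nM while compound 2 (`CCCCOc1ccc(-c2c(C)[nH]c(=O)n2C)cc1`) reads 5100 nM and compound 3 (`CCCCCc1ccc(-c2c(C)[nH]c(=O)n2C)cc1`) reads 5900 nM and so lies within the scatter of both others. The change to compound 4 (`CCCCCCCCCCCCCCc1ccc(-c2c(C)[nH]c(=O)n2C)cc1`) is nonyl in place of hydrogen on a saturated chain carbon, five bonds along the chain from an aromatic carbon and the shared core stays. The nearest chain step, a 1.8-fold lower number from compound 1 to compound 3 (0.26 log units; within the scatter), stays within the scatter. The step of a 2.1-fold lower number from compound 1 to compound 2 (0.32 log units; beyond the scatter) is modest, and a 1.2-fold higher number from compound 2 to compound 3 (0.06 log units; within the scatter) is again within the scatter. Among the compounds with values here, no measured step covers an addition of this length, so the read-across is weak. The expected change is a 2.4-fold lower number from compound 3 to compound 4 (0.37 log units; beyond the scatter) and its direction rests on that slight trend alone. Compound 4 is estimated at 2500 nM (expected range 400 nM to 15000 nM).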

Compound 4, half-maximal inhibitory concentration: 43800 nM
Beside the measured number, compound 4's estimate is 18-fold (1.24 log units) below it, outside the stated range (above it).
By their numbers in this assay, from the lowest: compounds 2, 3 and 1 (each within the scatter of the next, the first and the last beyond it); then compound 4.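

In this assay, nonyl in place of hydrogen on a saturated chain carbon, five bonds along the chain from an aromatic carbon, gives a 7.4-fold higher number from compound 3 to compound 4 (0.87 log units; beyond the scatter), so lengthening the chain here does not hold the number steady. The shorter chain step, a 1.8-fold lower number from compound 1 to compound 3 (0.26 log units; within the scatter), gave no sign of a rise of this size. Chain length at this position can therefore weaken inhibition, at least over this long addition.

Still open, on these data alone, is how a hexyl or octyl chain would read, and so where along the chain the number starts to rise. No measurement at hand bears on the reason for the rise.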